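A few compounds are considered here, and "the series" means these few. Any claim that something is new, unique, unknown or untested is made for them only; others in the source may bear on it.

Measured compounds:
Compound 1, `CNc1ncnc2c1c(-c1ccoc1)cn2[C@@H]1O[C@H](CO)[C@@H](O)[C@H]1O`: > 20000 nM
Compound 2, `Cc1ncnc2c1c(-c1ccoc1)cn2[C@@H]1O[C@H](CO)[C@@H](O)[C@H]1O`: > 20000 nM

In a functional assay on K562 cells (Homo sapiens), read by MTT assay, with a stated time of 72 h (a higher number here means a weaker inhibitor, a lower number a stronger inhibitor), compound 1 gives > 20000 nM, which is a limit of the assay rather than a number. Compound 2 likewise gives > 20000 nM in this assay, again only a limit. Within the data shown here, the one step between them, a step that the two limits leave unreadable from compound 1 to compound 2, cannot be read, since both values sit at the limit of > 20000 nM in this assay, at which 2 of the 2 values shown sit. Compound 2 therefore stands at that limit, with no numeric value that would let it be ranked against anything.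

The unmeasured compound 3, `Cc1ncnc2c1c(I)cn2[C@@H]1O[C@H](CO)[C@@H](O)[C@H]1O`, differs from compound 2 by iodo in place of furan-3-yl on an aromatic carbon. Among the measured compounds shown here, no measured step bears on this change: the only step available concerns a different position and is itself unreadable. The expectation for compound 3 in this assay therefore rests on nothing more than the two limits already seen, and compound 3 is estimated at 20000 nM, with a range from 6000 nM to 60000 nM. The expected step is a number no higher from compound 2 to compound 3 (the limit leaves the size open), which would most likely leave compound 3 at the same limit as well.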

Compound 3, half-maximal inhibitory concentration: 17800 nM
Compound 3: the middle estimate sits 1.1-fold (0.05 log units) above what was measured, and the stated range covers the measured number.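

In this assay compound 3 gives 17800 nM, the only numeric value among the three compounds shown, so iodo on this aromatic carbon, in place of furan-3-yl, gives a result that can be placed on the scale. Compound 2 gives > 20000 nM, which is a limit of the assay and not a number. The change therefore reads as an at least 1.1-fold lower number from compound 2 to compound 3 (0.05 log units; that floor lies within the scatter), so replacing the five-membered aromatic ring with a single iodine atom shows no loss at this position, but only a floor is known and it does not establish a real gain.

The compounds shown leave open how large this step really is, and whether the methylamino group of compound 1 would give a readable value with iodo on the same carbon. They also leave open how other groups would read on this carbon, such as bromo, a nitrile or a phenyl ring, and so whether the value of compound 3 is particular to iodo.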